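The source may hold more compounds than are shown below. What is called first, only, known or untested is meant among the compounds shown, and "the series" means these compounds.

Measured compounds:

Compound 1, `c1ccc(Cn2c(-c3nc4ccccc4[nH]3)cc3ccccc32)cc1`: in a functional assay on T47D cells (Homo sapiens) for antiproliferative activity, read by MTT assay, with a stated time of 48 h (on this read-out lower numbers stand for stronger inhibition and higher numbers for weaker inhibition), compound 1 gives 21500 nM.
Compound 3, `c1ccc2[nH]c(-c3nc4ccccc4[nH]3)cc2c1`: in this assay compound 3 gives 6200 nM.
Compound 2, `Brc1cnc2[nH]c(-c3cc4ccccc4n3Cc3ccccc3)nc2c1`: in this assay compound 2 gives "not determined" (no result reported), that is, no result is reported for it.

Compound 1 and compound 3 share the same core and differ in one place: the change is hydrogen in place of benzyl on an aromatic nitrogen. The step that this change made is a 3.5-fold lower number from compound 1 to compound 3 (0.54 log units; beyond the scatter), so here removing the benzyl went together with stronger inhibition.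

Compound 2 carries a different core; how its core differs from that of compound 1 is not broken down here. Compound 4, `Brc1cnc2[nH]c(-c3cc4ccccc4[nH]3)nc2c1`, has not yet been measured in this assay. It stands to compound 2 as compound 3 stands to compound 1: the change is hydrogen in place of benzyl on an aromatic nitrogen. The surroundings are not quite the same: in compound 1 the nitrogen sits next to the ring atom that bears a group of 9 heavy atoms, while in compound 2 it sits next to the ring atom that bears a large group, so this is the same kind of change rather than the same change.

For the measured compounds named here, no number exists for compound 2, so no step can be built from compound 2 to compound 4, and the earlier step from compound 1 to compound 3 stands alone. The expectation for compound 4 can rest only on compound 3, whose value of 6200 nM belongs to the closest measured analogue. Compound 4 is expected to give about 6000 nM in this assay, with a wide range from 1500 nM to 25000 nM, since the core differs and nothing shows how that core behaves.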

Compound 4, half-maximal inhibitory concentration: 21000 nM
Estimate against measurement, compound 4: 3.5-fold (0.54 log units) below; the range from low to high includes it.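

For the compounds shown here, with no result for compound 2 in this assay, no step from compound 2 to compound 4 can be read, even though compound 4 gives 21000 nM there. From the compounds shown here alone, what stays open is whether hydrogen in place of benzyl on the core of compound 2 would match a 3.5-fold lower number from compound 1 to compound 3 (0.54 log units; beyond the scatter) in size and direction or differ from it. No measured evidence shown here bears on the value of compound 4.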